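The source may report more compounds than this note shows. Statements on the series, on what has been measured and on what is new or still open speak of the compounds shown alone.

Measured in a functional assay on A-375 cells (Homo sapiens) for cytotoxicity, read by MTT assay; a lower number here means a stronger inhibitor, a higher number a weaker inhibitor:
- compound 1 `C=CCOc1cc(/C=C/C(=O)c2ccc(OC)c3c2OC(C)(C)C=C3)ccc1OC`: > 10000 nM, a limit of the assay
- compound 2 `COc1ccc(/C=C/C(=O)c2ccc(OC)c3c2OC(C)(C)C=C3)cc1OCCCN(C)C`: 4100 nM
- compound 3 `COc1ccc(/C=C/C(=O)c2ccc(OC)c3c2OC(C)(C)C=C3)cc1OC(=O)C(C)C`: 310 nM

Compound 3 holds the lowest number in this small set. The nearest actual number lies a large step away, a 13-fold lower number from compound 2 to compound 3 (1.12 log units; beyond the scatter). The gap to the limit is also large, an at least 32-fold lower number from compound 1 to compound 3 (1.50 log units; beyond the scatter).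

Compound 4 `COc1ccc(/C=C/C(=O)c2ccc(OC)c3c2OC(C)(C)C=C3)cc1CS(C)(=O)=O` has not yet been measured. It carries (methylsulfonyl)methyl in place of (isopropylcarbonyl)oxy on an aromatic carbon, ortho to a methoxy group: (methylsulfonyl)methyl in place of (isopropylcarbonyl)oxy on an aromatic carbon.

Among the measured compounds shown here, no measured compound carries the entering group, so the evidence is indirect. Both measured replacements of the (isopropylcarbonyl)oxy group's acyl part gave higher numbers than compound 3, as a 13-fold lower number from compound 2 to compound 3 (1.12 log units; beyond the scatter) and an at least 32-fold lower number from compound 1 to compound 3 (1.50 log units; beyond the scatter) show read in reverse. Those two compounds also differ from each other, an at least 2.4-fold lower number from compound 1 to compound 2 (0.38 log units; beyond the scatter), so the outcome depends on what is attached at this place.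

A moderate to large move toward a higher number in this assay is therefore expected, with some chance of reaching (the limit of > 10000 nM in this assay, at which 1 of the 3 values shown sits). The expected change is an 8.1-fold higher number from compound 3 to compound 4 (0.91 log units; beyond the scatter). The estimated value for compound 4 is 2500 nM, with an expected range of 400 nM to 10000 nM.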

Compound 4, half-maximal inhibitory concentration: > 10000 nM
Compound 4: a limit, no number (the forecaster's own chance of this, stated with the estimate: 20%); at least 4.0-fold (0.60 log units) between middle value and limit.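

Among the compounds shown here, compound 4 sits at a limit of the assay, and it is the only compound here whose group at this aromatic carbon is joined through carbon rather than oxygen: the limit of > 10000 nM in this assay, at which 2 of the 4 values shown sit. Exchanging (isopropylcarbonyl)oxy for (methylsulfonyl)methyl gives an at least 32-fold higher number from compound 3 to compound 4 (1.50 log units; beyond the scatter), and exchanging 3-(dimethylamino)propoxy for it gives an at least 2.4-fold higher number from compound 2 to compound 4 (0.38 log units; beyond the scatter), so the new group falls behind both the best compound and the weaker amine-bearing one. The leaving and entering groups have matching hydrogen-bond donor and acceptor counts and neither carries a net charge, so these counts do not separate compound 3 from compound 4, while the step between compound 1 and compound 4 cannot be read, since both values are limits.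

The compounds shown leave open whether the result follows from the carbon link or from the methylsulfonyl part itself, and a methylsulfonyl-bearing chain joined through oxygen would separate the two. They also leave open whether the value of compound 3 depends on its ester link, which a free hydroxyl or an amide at this carbon would test.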